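Compound 1 to compound 4: cyclopentyl on the aromatic nitrogen

The compounds below may be only part of what the source reports. "The series", "measured", "known", "first", "only" and "open" are said of these compounds alone.

Values in a functional assay on FaDu cells (Homo sapiens) for cytotoxicity, read by MTT assay, with a stated time of 72 h; a lower number here means that less compound is tolerated, a higher number that more compound is tolerated:
- compound 1 `COc1ccc(NC(=O)C(=O)c2cn(C(C)(C)COCC(=O)O)c3ccccc23)cn1`: > 10000 nM (a limit)
- compound 2 `COc1ccc(NC(=O)C(=O)c2cn(C(C)C)c3ccccc23)cc1`: 181 nM
- compound 3 `CC(C)n1cc(C(=O)C(=O)Nc2ccc(C(F)(F)F)nc2)c2ccccc21`: > 10000 nM (a limit)

Compound 1 gives only a limit, not a number: the limit of > 10000 nM in this assay, at which 2 of the 3 values shown sit. Compound 4 `COc1ccc(NC(=O)C(=O)c2cn(C3CCCC3)c3ccccc23)cn1`, not yet measured, carries cyclopentyl on the aromatic nitrogen in place of the group in compound 1: a group of 5 heavy atoms (5 carbon; one five-membered non-aromatic ring of carbon only) in place of a group of 9 heavy atoms (6 carbon, 3 oxygen; no ring), on an aromatic nitrogen. Among the compounds with values here, no measured step isolates this change. Compound 2 also lacks the leaving group and gives 181 nM, so a large step toward a lower number is expected in this assay. Compound 3 also lacks that group, yet gives > 10000 nM, which is a limit, so the expectation stays uncertain. The estimated change is an at least 33-fold lower number from compound 1 to compound 4 (1.52 log units; beyond the scatter). For compound 4 the expected value is 300 nM, with an estimated range of 40 nM to 3000 nM.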

Compound 4, concentration lethal to 50% of the cells: 370 nM
Beside the measured number, compound 4's estimate is 1.2-fold (0.09 log units) below it; the measured number falls inside the stated range.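

In this assay, within the data shown here, cyclopentyl on the aromatic nitrogen in place of the group in compound 1 gives an at least 27-fold lower number from compound 1 to compound 4 (1.43 log units; beyond the scatter), the first step between two compounds that differ in one place. Compound 1 gives > 10000 nM, which is a limit. The size of the step is therefore only a bound: the limit of > 10000 nM in this assay, at which 2 of the 4 values shown sit.

From the compounds shown here alone, whether the lower number comes from cyclopentyl itself or simply from the departure of the larger group stays open. Also open, going by these compounds, is how cyclohexyl or an aminoethyl chain on that nitrogen would read.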